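A few compounds are considered here, and "the series" means these few. Any claim that something is new, unique, unknown or untested is made for them only; others in the source may bear on it.

Measured compounds:
compound 1 `CCOC(=O)c1cnn(CC(O)CC)c1NC(=O)Nc1ccccc1F` gives 0.0016 nM;
compound 2 `CCOC(=O)c1cnn(CC(C)O)c1NC(=O)Nc1ccccc1F` gives 0.00055 nM;
compound 3 `CCCC(O)Cn1ncc(C(=O)OCC)c1NC(=O)NCc1ccccc1` gives 0.0032 nM.

All three were run in a functional assay on cells (Neutrophil, Homo sapiens) for inhibition, with a stated time of 10 min; a higher number here means a weaker inhibitor, a lower number a stronger inhibitor. Compound 1 and compound 2 share a core and differ by hydrogen in place of methyl on a saturated chain carbon, two bonds along the chain from an oxygen on a saturated carbon; this gave a 2.9-fold lower number from compound 1 to compound 2 (0.46 log units; beyond the scatter). Compound 3 differs from compound 1 in more than one place, and the difference between the two cores is not broken down here. Its value sits within the scatter of compound 1 and beyond it relative to compound 2.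

Compound 4 `CCOC(=O)c1cnn(CC(O)CC)c1NC(=O)NCc1ccccc1` is not yet measured in this assay. It differs from compound 3 by hydrogen in place of methyl on a saturated chain carbon, three bonds along the chain from an oxygen on a saturated carbon. This is the same kind of change as that from compound 1 to compound 2, but not the same: there the place is two bonds along the chain from an oxygen on a saturated carbon, here three bonds along. Resting on the earlier step, a step of similar direction but uncertain size is expected, estimated as a 2.0-fold lower number from compound 3 to compound 4 (0.30 log units; within the scatter). Compound 4 is therefore expected to give 0.0016 nM, between 0.0006 nM and 0.005 nM.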

Compound 4, half-maximal inhibitory concentration: 0.0074 nM
Compound 4: middle estimate off by 4.6-fold (0.67 log units), on the low side; measured number above the stated range.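

In this assay, hydrogen in place of methyl does not carry over from one core to the other with a common direction: the same change on two cores in this assay, a 2.9-fold lower number (0.46 log units; beyond the scatter) from compound 1 to compound 2 and a 2.3-fold higher number (0.36 log units; beyond the scatter) from compound 3 to compound 4, 6.7-fold (0.83 log units) apart, beyond the scatter of two such steps

On the core of compound 3 the step reads a 2.3-fold higher number from compound 3 to compound 4 (0.36 log units; beyond the scatter), while benzyl in place of 2-fluorophenyl on an amide-type nitrogen gives a 4.6-fold higher number from compound 1 to compound 4 (0.67 log units; beyond the scatter), so a step measured on one of these cores gives no safe forecast for the other. What this does not show is the source of the reversal: the place of the change also differs, two bonds along the chain from the oxygen on a saturated carbon in one pair and three bonds along in the other, so the effects of core and place cannot be separated, and a single pair on each core supports no general rule.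

Open, going by these compounds, is how a longer chain on the hydroxyl-bearing side chain would behave on either core. Also open is whether an amine in place of that hydroxyl would keep the values of these compounds.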